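The compounds below may be only part of what the source reports. "The series", "measured", "known", "first", "only" and "open" are said of these compounds alone.

Compound 1, `COc1ccc(COC(=O)c2cccc(S)n2)cc1`: 95000 nM
Compound 2, `O=C(OCc1ccccc1Br)c1cccc(=O)[nH]1`: 59000 nM
Compound 3, `COc1ccc(COC(=O)c2cccc(=O)[nH]2)cc1`: 100000 nM

These three compounds were tested in an assay on isolated protein for inhibition of matrix metalloproteinase-9 (Homo sapiens); on this read-out higher numbers stand for weaker inhibition and lower numbers for stronger inhibition. Compound 3 has the highest of the three numbers, but its gap to compound 1 and its gap to compound 2 both lie within the usual scatter of this assay, so the three cannot be ranked against each other. Compound 4, `O=C(OCc1ccc(C(F)(F)F)cc1)c1cccc(=O)[nH]1`, differs from compound 3 in one place: trifluoromethyl in place of methoxy on an aromatic carbon. Among the measured compounds shown here, no pair of measured compounds shows the effect of such a change, so nothing measured points to a direction. The step from compound 3 to compound 4 in this assay is expected to stay within the scatter, as a 1.2-fold lower number from compound 3 to compound 4 (0.07 log units; within the scatter). Compound 4 is therefore estimated to give 85000 nM, with a range from 40000 nM to 180000 nM.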

Compound 4, half-maximal inhibitory concentration: 101000 nM
Compound 4: middle estimate off by 1.2-fold (0.07 log units), on the low side, and the stated range covers the measured number.
By their numbers in this assay, from the lowest: compounds 2, 1, 3 and 4 (each within the scatter of the next).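

In this assay, placing trifluoromethyl in place of methoxy on this aromatic carbon, para to a large group, gives a 1.0-fold higher number from compound 3 to compound 4 (0.00 log units; within the scatter). Among the compounds shown here, this is the first direct reading at this position, and it shows that this exchange of groups leaves no difference that the assay can detect, even though the two groups differ in their atoms and in their hydrogen-bond acceptor count. Nothing measured offers an explanation for this result.

As far as these compounds go, whether an amine or a carboxylic acid on this same carbon would give a number beyond the scatter remains open.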